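The source may report more compounds than this note shows. Statements on the series, on what has been measured and on what is new or still open speak of the compounds shown alone.

Compound 1 `CC(C)(C)c1ccc(C(=O)NCc2ccc(-c3nnn[nH]3)cc2)cc1` gives 120 nM in an assay on HeLa cells with Bile acid receptor (Homo sapiens) as the target, read by a luciferase reporter, with a stated time of 24 h; a lower number here means that less compound is needed, a higher number that more compound is needed for the effect. Compound 2 `CC(C)(C)c1ccc(C(=O)NCc2ccc(OCC(=O)O)cc2)cc1` gives 730 nM in this assay; the step of a 6.1-fold higher number from compound 1 to compound 2 (0.78 log units; beyond the scatter) is the only measured one, and compound 2 stands at the higher of the two numbers. Compound 3 `CC(=O)c1ccc(CNC(=O)c2ccc(C(C)(C)C)cc2)cc1` carries acetyl in place of carboxymethoxy on an aromatic carbon. Among the measured compounds shown here, the step of a 6.1-fold higher number from compound 1 to compound 2 (0.78 log units; beyond the scatter) is the sole guide, since it exchanges the group at the same position, so a further step of comparable or larger size in this assay is expected, towards a higher number, as a 2.7-fold higher number from compound 2 to compound 3 (0.44 log units; beyond the scatter). For compound 3 the expected value in this assay is 2000 nM, within 400 nM to 10000 nM.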

Compound 3, half-maximal effective concentration: 100 nM
For compound 3 the middle estimate is 20-fold (1.30 log units) above the measured one, outside the stated range (below it).
By their numbers in this assay, from the lowest: compounds 3 and 1 (each within the scatter of the next); then compound 2.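

On this aromatic carbon, para to a large group, replacing carboxymethoxy with the smaller acetyl gives a 7.3-fold lower number from compound 2 to compound 3 (0.86 log units; beyond the scatter) in this assay, reversing the direction of the first step. Acetyl and 1H-tetrazol-5-yl show a 1.2-fold lower number from compound 1 to compound 3 (0.08 log units; within the scatter), so 1H-tetrazol-5-yl is not required for a number at this level. No measurement at hand explains why carboxymethoxy stands apart from the other two groups.

Still open, going by these compounds, is whether the number depends on the carbonyl of acetyl. A carboxylic acid, an amine or a longer acyl chain such as propanoyl at this place would bear on that.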